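The compounds below may be only part of what the source reports. "The series", "measured", "known", "first", "only" and "open" are said of these compounds alone.

Three compounds share one core and differ only in the group that sits on one aromatic carbon of the arm bound to sulfur. In a functional assay on MCF7 cells (Homo sapiens) for inhibition, read by MTT assay, with a stated time of 72 h (on this read-out higher numbers stand for weaker inhibition and lower numbers for stronger inhibition), compound 1 `Cc1cc(Nc2cc(-c3ccccc3)[nH]n2)n2nc(SCc3ccc(F)cc3)nc2n1` gives 4020 nM, compound 2 `Cc1cc(Nc2cc(-c3ccccc3)[nH]n2)n2nc(SCc3ccc(Br)cc3)nc2n1` gives 2720 nM, and compound 3 `Cc1cc(Nc2cc(-c3ccccc3)[nH]n2)n2nc(SCc3ccc(C(F)(F)F)cc3)nc2n1` gives 4820 nM. Compound 2 has the smallest of the three numbers, yet a 1.5-fold lower number from compound 1 to compound 2 (0.17 log units; within the scatter) and a 1.8-fold higher number from compound 2 to compound 3 (0.25 log units; within the scatter) both fall within the scatter, as does a 1.2-fold higher number from compound 1 to compound 3 (0.08 log units; within the scatter), so the three cannot be told apart on this read-out.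

Compound 4 `Cc1cc(Nc2cc(-c3ccccc3)[nH]n2)n2nc(SCc3csc4ccccc34)nc2n1` has not been measured in this assay. It differs from compound 2 as follows: 1-benzothiophen-3-yl in place of 4-bromophenyl on a saturated chain carbon bound to a sulfur. Within the data shown here, every measured step only exchanged one substituent for another on the aromatic carbon, and each stayed within the scatter; no measured pair exchanges the whole ring as this change does, so there is no direct guide to its size or direction. Given that every swap at this position so far left the number unchanged within the scatter, the expectation for compound 4 is a step of a 1.1-fold higher number from compound 2 to compound 4 (0.04 log units; within the scatter), with a broad range. Compound 4 is therefore estimated at 3000 nM, between 1000 nM and 9000 nM.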

Compound 4, half-maximal inhibitory concentration: 3470 nM
Compound 4: the middle estimate sits 1.2-fold (0.06 log units) below what was measured, and the stated range covers the measured number.
By their numbers in this assay, from the lowest: compounds 2, 4, 1 and 3 (each within the scatter of the next).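

Among these compounds, replacing the whole ring, rather than one substituent on it, also produces no step that can be told from the scatter in this assay: there is a 1.3-fold higher number from compound 2 to compound 4 (0.11 log units; within the scatter) and a 1.4-fold lower number from compound 3 to compound 4 (0.14 log units; within the scatter) and also a 1.2-fold lower number from compound 1 to compound 4 (0.06 log units; within the scatter) on this read-out. The change brings in 1-benzothiophen-3-yl, which adds a five-membered aromatic ring holding a sulfur atom to the six-membered ring of carbon, so the insensitivity seen earlier for swaps on the phenyl ring now extends to a change of the ring system itself, at least for these four compounds. No measurement is available that would explain this lack of difference.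

As far as these compounds go, all four compounds carry an aromatic group on the saturated chain carbon bound to a sulfur, so it remains open whether a basic amine, a carboxylic acid or a simple alkyl chain in that place would shift the number beyond the scatter. The methyl and phenyl groups on the shared core stay the same throughout, which leaves open how much the number depends on those parts.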